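A few compounds are considered here, and "the series" means these few. Any claim that something is new, unique, unknown or untested is made for them only; others in the source may bear on it.

Working notes on the series, measured in a functional assay on MCF7 cells (Homo sapiens) for cytotoxicity, read by MTT assay, with a stated time of 48 h; a lower number here means a stronger inhibitor, a higher number a weaker inhibitor.

Compound 1 `COc1ccc(/C=C2/S/C(=N/c3ccccc3)N(Cc3ccncc3)C2=O)cc1` gives 31500 nM in this assay. Compound 2 `O=C1/C(=C\c2ccc(Cl)cc2)S/C(=N/c2ccccc2)N1Cc1ccncc1` gives 54900 nM in this assay, and compound 3 `CCOc1cc(/C=C2/S/C(=N/c3ccccc3)N(Cc3ccncc3)C2=O)ccc1O` gives 20100 nM in this assay. Compound 1 thus stands second highest of the three numbers, with compound 3 nearest and compound 2 furthest, both within the scatter, as shown by a 1.6-fold lower number from compound 1 to compound 3 (0.20 log units; within the scatter) and a 1.7-fold higher number from compound 1 to compound 2 (0.24 log units; within the scatter).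

Compound 4 `O=C1/C(=C\c2cccc(O)c2)S/C(=N/c2ccccc2)N1Cc1ccncc1` differs from compound 1 as follows: 3-hydroxyphenyl in place of 4-methoxyphenyl on a double-bonded chain carbon bound to a double-bonded ring carbon. The nearest comparison is the arrival of a hydroxy-bearing ring in compound 3, seen in a 1.6-fold lower number from compound 1 to compound 3 (0.20 log units; within the scatter) and, beyond the scatter, in a 2.7-fold lower number from compound 2 to compound 3 (0.44 log units; beyond the scatter). Compound 4 carries the hydroxy without the ethoxy, so those steps bear on it only loosely. Expected for compound 4 is a step of a 1.3-fold lower number from compound 1 to compound 4 (0.10 log units; within the scatter), most likely within the scatter, with a slight lean toward a lower number. The estimate for compound 4 is 25000 nM, in the range 10000 nM to 60000 nM.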

Compound 4, half-maximal inhibitory concentration: 43600 nM
Beside the measured number, compound 4's estimate is 1.7-fold (0.24 log units) below it; low and high end bracket the measured number.
By their numbers in this assay, from the lowest: compounds 3, 1, 4 and 2 (each within the scatter of the next, the first and the last beyond it).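

In this assay, the 3-hydroxyphenyl group gives a 1.4-fold higher number from compound 1 to compound 4 (0.14 log units; within the scatter) and a 1.3-fold lower number from compound 2 to compound 4 (0.10 log units; within the scatter), so this hydroxy-bearing ring cannot be told apart from the 4-methoxyphenyl or 4-chlorophenyl group at this position. The step beyond the scatter is a 2.2-fold higher number from compound 3 to compound 4 (0.34 log units; beyond the scatter), which shows that a hydroxy-bearing ring does not by itself match the number given by the 3-ethoxy-4-hydroxyphenyl group. Nothing available on these compounds explains this difference.

Still open is which part of the 3-ethoxy-4-hydroxyphenyl group accounts for this gap, the ethoxy or the placing of the hydroxy. The compounds shown also leave open how an amine, a carboxylic acid or a longer chain in place of the ethoxy would behave on this ring.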